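This account rests on a few compounds, and the source may have more. Where it says the series, first, only, none or still open, it means among the compounds named here.

Measured compounds:
- compound 1 `CCC/C=C\C(=O)Nc1cc(Nc2nccc(-c3cn(C)c4ccccc34)n2)c(OC)cc1N(C)CCN(C)C`; in a functional assay on HepG2 cells (Homo sapiens) for antiproliferative activity, read by MTT assay, with a stated time of 72 h (on this read-out lower numbers stand for stronger inhibition and higher numbers for weaker inhibition), compound 1 gives 431 nM
- compound 2 `CCC/C=C\C(=O)Nc1cc(Nc2ncc(C#N)c(-c3cn(C)c4ccccc34)n2)c(OC)cc1N(C)CCN(C)C`; in this assay compound 2 gives 1690 nM
- compound 3 `C=CC(=O)Nc1cc(Nc2nccc(-c3cn(C)c4ccc(F)cc34)n2)c(OC)cc1N(C)CCN(C)C`; in this assay compound 3 gives 429 nM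

Compound 1 and compound 2 differ in one place: cyano in place of hydrogen on an aromatic carbon. This change gave a 3.9-fold higher number from compound 1 to compound 2 (0.59 log units; beyond the scatter). The values of compound 1 and compound 3 lie within the usual scatter of each other, so nothing is made of their order; the difference between the two cores is not broken down here.

Compound 4 `C=CC(=O)Nc1cc(Nc2ncc(C#N)c(-c3cn(C)c4ccc(F)cc34)n2)c(OC)cc1N(C)CCN(C)C` is not yet measured. It stands to compound 3 as compound 2 stands to compound 1: cyano in place of hydrogen on an aromatic carbon. The surroundings are not identical, since in compound 4 the entering group sits ortho to a 5-fluoro-1-methyl-1H-indol-3-yl group, whereas in compound 2 it sits ortho to a 1-methyl-1H-indol-3-yl group, so this is the same kind of change rather than the same change. Among the measured compounds shown here, with only one earlier example, the expectation rests on it: a step of about a 3.7-fold higher number from compound 3 to compound 4 (0.57 log units; beyond the scatter) is expected, beside the earlier 3.9-fold higher number from compound 1 to compound 2 (0.59 log units; beyond the scatter). Compound 4 is therefore estimated at 1600 nM, within 700 nM to 3800 nM.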

Compound 4, half-maximal inhibitory concentration: 17500 nM
Compound 4: the middle estimate sits 11-fold (1.04 log units) below what was measured; the whole stated range lies below it.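

In this assay the cyano in place of hydrogen gave a 41-fold higher number from compound 3 to compound 4 (1.61 log units; beyond the scatter), so on both cores shown the change moved the number the same way, but its size did not carry over: the same change on two cores in this assay, a 3.9-fold higher number (0.59 log units; beyond the scatter) from compound 1 to compound 2 and a 41-fold higher number (1.61 log units; beyond the scatter) from compound 3 to compound 4, 10-fold (1.02 log units) apart, beyond the scatter of two such steps. On these two pairs, the direction of the step on one core is a better guide than its size, although two pairs are too few to establish a rule for the series. The cores of compound 1 and compound 3 differ both in the acyl chain on the amide and in the 5-fluoro-1-methyl-1H-indol-3-yl group, so these data do not show which difference goes with the larger step, or why the steps differ.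

Still open, going by these compounds, is the size of the cyano step on a core that carries the fluorine with the longer acyl chain, or the shorter chain without the fluorine. Also open, on these data alone, is whether a chlorine or a methyl at the same ring carbon would follow the cyano steps.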